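This account rests on a few compounds, and the source may have more. Where it says the series, first, only, none or still open, it means among the compounds named here.

Series notes. Three compounds sharing one core have been run in an assay on HEK293 cells for displacement of a labelled ligand from NPC1-like intracellular cholesterol transporter 1 (Homo sapiens); on this read-out lower numbers stand for stronger inhibition and higher numbers for weaker inhibition. Compound 1, `CC(C)(C)c1ccc(C(=O)N2CCC3(CC2)C(=O)N(CC(=O)N2CCNCC2)CN3c2ccccc2)cc1`, gives 22000 nM. Compound 2, `CCOC(=O)C1CCN(C(=O)CN2CN(c3ccccc3)C3(CCN(C(=O)c4ccc(C(C)(C)C)cc4)CC3)C2=O)CC1`, gives 3100 nM. Compound 3, `CCOC(=O)C1CCCN(C(=O)CN2CN(c3ccccc3)C3(CCN(C(=O)c4ccc(C(C)(C)C)cc4)CC3)C2=O)C1`, gives 8200 nM. Compound 3 stands second highest of the three numbers: a 2.6-fold higher number from compound 2 to compound 3 (0.42 log units; beyond the scatter), while a 2.7-fold lower number from compound 1 to compound 3 (0.43 log units; beyond the scatter).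

Compound 4, `CC(C)(C)c1ccc(C(=O)N2CCC3(CC2)C(=O)N(CC(=O)N2CCCCC2CO)CN3c2ccccc2)cc1`, has not yet been run in this assay. Compared with compound 3 the change is 2-(hydroxymethyl)piperidin-1-yl in place of 3-(ethoxycarbonyl)piperidin-1-yl on a carbonyl carbon.

All three measured steps concern the same position, the ring on that carbonyl carbon, and all were modest: a 7.1-fold lower number from compound 1 to compound 2 (0.85 log units; beyond the scatter), a 2.7-fold lower number from compound 1 to compound 3 (0.43 log units; beyond the scatter), a 2.6-fold higher number from compound 2 to compound 3 (0.42 log units; beyond the scatter). The lowest number belongs to compound 2 and the highest to compound 1, which lacks an ethoxycarbonyl group altogether. Compound 4 also lacks an ethoxycarbonyl group, so a move back toward the number of compound 1 is expected rather than a further drop, of a size comparable to the measured steps and beyond the scatter. The step of a 1.5-fold higher number from compound 3 to compound 4 (0.17 log units; within the scatter) is the expected one. Compound 4 is accordingly estimated at 12000 nM, with a range from 4000 nM to 40000 nM.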

Compound 4, half-maximal inhibitory concentration: 11800 nM
Beside the measured number, compound 4's estimate is 1.0-fold (0.01 log units) above it; measured number inside the range.
By their numbers in this assay, from the lowest: compound 2; then compounds 3, 4 and 1 (each within the scatter of the next, the first and the last beyond it).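

In this assay, the 2-(hydroxymethyl)piperidin-1-yl group of compound 4 cannot be told apart from the 3-(ethoxycarbonyl)piperidin-1-yl group (a 1.4-fold higher number from compound 3 to compound 4 (0.16 log units; within the scatter)) or from the piperazin-1-yl group (a 1.9-fold lower number from compound 1 to compound 4 (0.27 log units; within the scatter)), even though compounds 1 and 3 are separated from each other beyond the scatter. Among these compounds, only the 4-(ethoxycarbonyl)piperidin-1-yl group stands clear of the new compound (a 3.8-fold higher number from compound 2 to compound 4 (0.58 log units; beyond the scatter)), which leaves compound 2 as the one member of the set beyond the scatter of all the others, and shows that a ring on this carbonyl carbon with a hydrogen-bond donor and fewer heavy atoms does not match it. Nothing available explains these differences.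

Compound 4 differs from compounds 2 and 3 in both the substituent and its ring position, so the compounds shown do not separate the effect of the hydroxymethyl group from that of its place on the piperidine. Also open, from the compounds shown here alone, is whether the low number of compound 2 depends on the ester itself, a question that a carboxylic acid or a 4-(hydroxymethyl)piperidin-1-yl group on this carbonyl carbon would address.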